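Lengthening the alkylamino chain on a chloro-triazine herbicide scaffold

The compounds below may be only part of what the source reports. "The series", "measured", "known", "first", "only" and "open" are said of these compounds alone.

Two compounds share a chloro-substituted core that carries a phenylethylamino group and a second amino substituent. Compound 1, `CCN(CC)c1nc(Cl)nc(NC(C)c2ccccc2)n1`, bears a diethylamino group there; compound 2, `CCNc1nc(Cl)nc(N[C@@H](C)c2ccccc2)n1`, bears an ethylamino group instead. In an ADME assay on the whole organism for inhibition, with Echinochloa crus-galli var. formosensis as the target, with a stated time of 4 days (a lower number here means a stronger inhibitor, a higher number a weaker inhibitor), compound 1 gives 1510 nM. In this assay compound 2 gives 30900 nM, the higher of the two numbers, and the gap to compound 1 lies well beyond the usual scatter, so compound 2 is the weaker inhibitor of the pair.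

Compound 3, `CCCCNc1nc(Cl)nc(N[C@@H](C)c2ccccc2)n1`, has not yet been measured. It differs from compound 2 in one place: ethyl in place of hydrogen on a saturated chain carbon, two bonds along the chain from a nitrogen on an aromatic ring. Among the measured compounds shown here, no pair of measured compounds shows exactly this change, so the direction is not settled by the data. A modest move toward a lower number seems plausible for compound 3, since compound 1 with its larger diethylamino group gives 1510 nM. The expected step is a 3.1-fold lower number from compound 2 to compound 3 (0.49 log units; beyond the scatter). On that basis compound 3 is estimated at 10000 nM in this assay, within a range from 3000 nM to 40000 nM.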

Compound 3, half-maximal inhibitory concentration: 12900 nM
Compound 3: middle estimate off by 1.3-fold (0.11 log units), on the low side, within the range that was stated.
By their numbers in this assay, from the lowest: compound 1; then compound 3; then compound 2.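

Going from ethylamino to butylamino gives a 2.4-fold lower number from compound 2 to compound 3 (0.38 log units; beyond the scatter) in this assay, and this is the first single change in the series that can be read directly. It shows that this position, on a saturated chain carbon, two bonds along the chain from a nitrogen on an aromatic ring, accepts an added ethyl without a loss of inhibition, and that the longer chain makes compound 3 the stronger inhibitor of this pair. Nothing in the available data explains why the number falls, so the step stands as an observation and no more.

From the compounds shown here alone, a single step gives a direction but not a trend, so it remains open whether a longer hexyl chain would lower the number further, leave it about the same or raise it again. Going by these compounds, it also remains open how a branched isobutyl group, or a butyl chain ending in a hydroxyl group or an amine, would compare with the plain butylamino group of compound 3.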